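This account rests on a few compounds, and the source may have more. Where it says the series, first, only, none or still open, it means among the compounds named here.

Compound 1 `COc1ccc(C(=O)/C=C/c2ccc(F)cc2)c2c1C=CC(C)(C)O2` is a chalcone-type molecule carrying a 4-fluorophenyl group at the far end of its double-bonded chain. In a functional assay on SK-OV-3 cells (Homo sapiens) for antiproliferative activity, read by MTT assay, with a stated time of 24 h (on this read-out higher numbers stand for weaker inhibition and lower numbers for stronger inhibition), compound 1 gives > 10000 nM, which is a limit of the measurement rather than a number. Compound 2 `COc1ccc(C(=O)/C=C/c2ccc(OC)c(OC)c2OC)c2c1C=CC(C)(C)O2` shares the same core with a differently substituted benzene ring, and in this assay compound 2 gives > 10000 nM, again a limit. Both measured values therefore sit at the same ceiling (the limit of > 10000 nM in this assay, at which 2 of the 2 values shown sit), so compound 1 can only be placed at that boundary, with nothing seen that separates it from compound 2. Compound 3 `COc1ccc(C(=O)/C=C/c2cccs2)c2c1C=CC(C)(C)O2` has not yet been measured. It differs from compound 1 in one place: thiophen-2-yl in place of 4-fluorophenyl on a double-bonded chain carbon bound to a double-bonded chain carbon. Among the measured compounds shown here, with no measured step to lean on, the expectation is a step from compound 1 to compound 3 of a step that the limit leaves unreadable from compound 1 to compound 3, essentially none beyond the scatter. Compound 3 is expected to give 15000 nM, within 5000 nM to 50000 nM.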

Compound 3, half-maximal inhibitory concentration: > 10000 nM
Compound 3: no number, only a limit; the forecaster's own chance of this, stated with the estimate: 70%; the middle value lies beyond the limit too.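

Among the compounds shown here, compound 1 and compound 3 both stop at a limit rather than a number, so no step between them can be read. Left open is how strongly any compound shown inhibits cell growth, and whether thiophen-2-yl in place of 4-fluorophenyl changes that at all.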